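Benzyl Variation and Expected Tolerance in Cytotoxicity Testing

A few compounds are considered here, and "the series" means these few. Any claim that something is new, unique, unknown or untested is made for them only; others in the source may bear on it.

In an ADME assay on MT4 cells (Homo sapiens) for cytotoxicity, read by MTT assay, with a stated time of 5 days (a higher number here means that more compound is tolerated, a lower number that less compound is tolerated), the three measured compounds read as follows:
Compound 1, `Cc1cc(C)c(Oc2cc(Nc3ccc(C#N)cc3)ncc2C(=O)NCc2cn(Cc3ccccc3[N+](=O)[O-])nn2)c(C)c1`: > 212000 nM
Compound 2, `Cc1ccc(Cn2cc(CNC(=O)c3cnc(Nc4ccc(C#N)cc4)cc3Oc3c(C)cc(C)cc3C)nn2)cc1`: 165000 nM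
Compound 3, `Cc1cc(C)c(Oc2cc(Nc3ccc(C#N)cc3)ncc2C(=O)NCc2cn(Cc3ccccc3Cl)nn2)c(C)c1`: >= 188000 nM

Compound 3 stands at a limit of this assay, (the limit of >= 188000 nM in this assay, at which 1 of the 3 values shown sits), rather than at a number. Compound 1 likewise sits at a limit, (the limit of > 212000 nM in this assay, at which 1 of the 3 values shown sits). Compound 2 alone gives a number, and the steps that join the three are small: an at least 1.1-fold higher number from compound 2 to compound 3 (0.05 log units; that floor lies within the scatter), an at least 1.2-fold lower number from compound 1 to compound 2 (0.10 log units; that floor lies within the scatter), while a step that the two limits leave unreadable from compound 1 to compound 3. None of these exchanges of the group on the saturated chain carbon bound to an aromatic nitrogen has moved the read-out beyond the scatter.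

Compound 4, `Cc1cc(C)c(Oc2cc(Nc3ccc(C#N)cc3)ncc2C(=O)NCc2cn(Cc3ccc(F)cc3)nn2)c(C)c1`, carries the change (4-fluorophenyl in place of 2-chlorophenyl on a saturated chain carbon bound to an aromatic nitrogen). Within the data shown here, it is the same kind of exchange as the one from compound 2 to compound 3, which was within the scatter, so no step beyond the scatter is expected: an at least 1.0-fold lower number from compound 3 to compound 4 (0.01 log units; that floor lies within the scatter). Compound 4 is therefore estimated at 180000 nM, within a range from 110000 nM to 260000 nM, and it may well again be reported only as a limit.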

Compound 4, half-maximal cytotoxic concentration: >= 153000 nM
Compound 4: a limit, no number (the forecaster's own chance of this, stated with the estimate: 60%); the middle value is on the limit's open side.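

In this assay compound 4 gives >= 153000 nM, which is a limit and not a number. Its steps from compound 1, compound 2 and compound 3 cannot be read. The compounds shown leave open where compound 1, compound 3 and compound 4 truly stand relative to compound 2, the only one with a number.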